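A few compounds are considered here, and "the series" means these few. Any claim that something is new, unique, unknown or untested is made for them only; others in the source may bear on it.

Series notes. Compound 1 `NC(=O)[C@@H]1CC[C@H](c2cccc(OCc3ccccc3)c2)N1` carries a benzyl on an oxygen on an aromatic ring. In an assay on HEK293 cells for inhibition of sodium channel protein type 3 subunit alpha (Homo sapiens), read by electrophysiology, with a stated time of 3.5 min (a lower number here means a stronger inhibitor, a higher number a weaker inhibitor), compound 1 reaches only the limit > 100000 nM. Compound 2 `NC(=O)[C@@H]1CC[C@H](c2ccc(OCc3ccccc3)cc2)N1` has the same atoms joined differently; the difference between the two cores is not broken down here. In this assay compound 2 also stops at a limit, > 63000 nM. Compound 3 `NC(=O)[C@@H]1CC[C@H](c2cccc(Oc3ccccc3)c2)N1` arises from compound 1 by phenyl in place of benzyl on an oxygen on an aromatic ring. Compound 3 gives a limit as well, > 100000 nM. The step that the two limits leave unreadable from compound 1 to compound 3 cannot be read, since both values sit at the limit of > 100000 nM in this assay, at which 2 of the 3 values shown sit. Compound 4 `NC(=O)[C@@H]1CC[C@H](c2ccc(Oc3ccccc3)cc2)N1` stands to compound 2 as compound 3 stands to compound 1, the same change: phenyl in place of benzyl on an oxygen on an aromatic ring. For the measured compounds named here, with compound 2 at the limit of > 63000 nM in this assay, at which 1 of the 3 values shown sits, and the one precedent unreadable, the step from compound 2 to compound 4 is expected at a step that the limit leaves unreadable from compound 2 to compound 4, another limit being the likely outcome. Compound 4 is expected to give 100000 nM in this assay.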

Compound 4, half-maximal inhibitory concentration: 100000 nM
Compound 4: the middle estimate sits on the measured number at the digits printed; low and high end bracket the measured number.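

The step from compound 2 to compound 4 cannot be read, because compound 2 stops at a limit: the limit of > 63000 nM in this assay, at which 1 of the 4 values shown sits.

The compounds shown leave open whether phenyl in place of benzyl on an oxygen on an aromatic ring changes inhibition at all.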